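Shortening the Alkyl Chain of Compound 1

The compounds below may be only part of what the source reports. "The series", "measured", "known", "first", "only" and "open" are said of these compounds alone.

Within the data shown here, compound 1 `CC(/N=c1\c(O)c(O)\c1=N/c1ccc(C#N)cc1)C(C)(C)C` is the only compound here with a measured number: in a functional assay for inhibition, with Rattus norvegicus as the target (on this read-out higher numbers stand for weaker inhibition and lower numbers for stronger inhibition), compound 1 gives 520 nM. Compound 2 `CC(/N=c1\c(O)c(O)\c1=N/c1ccc(C(F)(F)F)cc1)C(C)(C)C` carries trifluoromethyl in place of cyano on an aromatic carbon, and in this assay compound 2 reaches only a limit, > 30000 nM. Among the measured compounds shown here, the step of an at least 57-fold higher number from compound 1 to compound 2 (1.76 log units; beyond the scatter) is the single measured step, and its size rests on (the limit of > 30000 nM in this assay, at which 1 of the 2 values shown sits). Compound 3 `CCC(C)/N=c1\c(O)c(O)\c1=N/c1ccc(C#N)cc1` keeps the cyano-bearing aryl part of compound 1 and differs from it elsewhere: ethyl in place of tert-butyl on a saturated chain carbon bound to a double-bonded nitrogen and a saturated chain carbon. For the measured compounds named here, the one measured step concerns the aromatic substituent and says nothing about the chain on the other side of the shared core, so no measured step bears on the change from compound 1 to compound 3. The change is a small one in size and adds or removes no donor or acceptor, so a modest step, possibly within the scatter, is expected rather than a large one: a 1.7-fold higher number from compound 1 to compound 3 (0.24 log units; within the scatter). Compound 3 is therefore estimated at 900 nM, with a range from 250 nM to 3500 nM.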

Compound 3, half-maximal inhibitory concentration: 2100 nM
Beside the measured number, compound 3's estimate is 2.3-fold (0.37 log units) below it; the range from low to high includes it.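

In this assay, the side of the shared core that carries the alkyl group also moves the number, and the change gives a 4.0-fold higher number from compound 1 to compound 3 (0.61 log units; beyond the scatter). Among these compounds, until this result, the only measured step lay on the aromatic substituent, so this is the first reading on the chain: with the cyano-bearing aryl part held constant, compound 1 with its tert-butyl group gives stronger inhibition than compound 3 with its ethyl group, and this position cannot be treated as indifferent to the group it carries. Nothing in the information at hand accounts for the size or direction of this step.

As far as these compounds go, it remains open whether the number keeps rising as the chain is cut further, to a methyl group or a lone hydrogen, or whether a longer chain such as n-hexyl or a ring such as cyclohexyl would bring it down again below that of compound 1. From the compounds shown here alone, it also remains open how a hydroxyl group, an amine or a carboxylic acid at the end of the chain would read, and whether the same chain change would have any comparable effect with a chloro or methoxy group on the aromatic ring in place of nitrile.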